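Removing the ester side chain from compound 3

The source may report more compounds than this note shows. Statements on the series, on what has been measured and on what is new or still open speak of the compounds shown alone.

In a functional assay on HL-60 cells (Homo sapiens) for inhibition, read by MTT assay, with a stated time of 2 days (a lower number here means a stronger inhibitor, a higher number a weaker inhibitor), compound 1 `C=C1CC[C@H]2C(C)(C)[C@H](O)CC[C@]2(C)[C@H]1C[C@]12O[C@H]1C(=O)C(COC(=O)[C@H](O)[C@H](C)O)=CC2=O` gives 2600 nM, compound 2 `C=C1CC[C@H]2C(C)(C)[C@H](O)CC[C@]2(C)[C@H]1C[C@]12O[C@H]1[C@H](O)C(COC(=O)[C@H](O)[C@H](C)O)=CC2=O` gives 21600 nM, and compound 3 `C=C1CC[C@H]2C(C)(C)[C@H](O)CC[C@]2(C)[C@H]1C[C@]12O[C@H]1[C@H](O)C(COC(=O)C[C@H](C)O)=CC2=O` gives 15000 nM. Compound 3 thus stands second highest of the three numbers: it sits within the scatter of compound 2 and beyond the scatter of compound 1, whose number is lower. For the measured compounds named here, the only step in this set that touches the ester side chain is a 1.4-fold lower number from compound 2 to compound 3 (0.16 log units; within the scatter), so altering a substituent on that chain made no difference beyond the scatter. Compound 4 `C=C1CC[C@H]2C(C)(C)[C@H](O)CC[C@]2(C)[C@H]1C[C@]12O[C@H]1[C@H](O)C(CO)=CC2=O` goes further: a hydrogen atom in place of a group of 6 heavy atoms (4 carbon, 2 oxygen; no ring), on an oxygen on a saturated carbon. Going by the values given here, no measured pair shows what loss of the whole ester does, so the direction is uncertain; the small effect of a 1.4-fold lower number from compound 2 to compound 3 (0.16 log units; within the scatter) suggests the chain is not decisive, but its complete removal is a larger change than any measured. Compound 4 is therefore expected to give about 20000 nM, with a range of 6000 nM to 70000 nM, corresponding to an estimated step of a 1.3-fold higher number from compound 3 to compound 4 (0.12 log units; within the scatter).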

Compound 4, half-maximal inhibitory concentration: 25300 nM
The estimate for compound 4 lay 1.3-fold (0.10 log units) below the measured number; the measured number falls inside the stated range.
By their numbers in this assay, from the lowest: compound 1; then compounds 3, 2 and 4 (each within the scatter of the next).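

In this assay, the earlier compounds had shown only that one hydroxy on the ester chain could be exchanged for hydrogen, whereas here the whole chain gives way to a hydrogen atom on the oxygen: a 1.7-fold higher number from compound 3 to compound 4 (0.23 log units; within the scatter), and with the larger ester as the starting point, a 1.2-fold higher number from compound 2 to compound 4 (0.07 log units; within the scatter). Both steps lie within the scatter, so on this core, carrying the hydroxy that these three compounds share, neither ester chain shows a measurable contribution to the number compared with the free hydroxy. No measurement shown here offers an explanation for this result.

The compounds shown leave open whether a longer chain, or a chain ending in an amine or a carboxylic acid, on this oxygen would move the number beyond the scatter. They also leave open whether removing the ester would matter equally on the core of compound 1.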